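From thiophen-2-yl to 1-benzofuran-2-yl at the assay limit

The compounds below may be only part of what the source reports. "The series", "measured", "known", "first", "only" and "open" are said of these compounds alone.

Of the compounds shown here, three sharing one core have been read so far: compound 1 (`CNc1ncnc2c1c(-c1cc3ccccc3o1)cn2[C@@H]1O[C@H](CO)[C@@H](O)[C@H]1O`), compound 2 (`Cc1ncnc2c1c(-c1ccoc1)cn2[C@@H]1O[C@H](CO)[C@@H](O)[C@H]1O`) and compound 3 (`Cc1ncnc2c1c(-c1cccs1)cn2[C@@H]1O[C@H](CO)[C@@H](O)[C@H]1O`).

In a functional assay on HCT-116 cells (Homo sapiens), read by MTT assay, with a stated time of 72 h (on this read-out lower numbers stand for stronger inhibition and higher numbers for weaker inhibition), compound 1 gives > 20000 nM, which is a limit and not a number. In this assay compound 2 gives > 20000 nM, again a limit. In this assay compound 3 gives > 20000 nM, also a limit, so compound 3 has no number of its own and stands only as a limit.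

The next compound is compound 4 (`Cc1ncnc2c1c(-c1cc3ccccc3o1)cn2[C@@H]1O[C@H](CO)[C@@H](O)[C@H]1O`), reached from compound 3 by the change (1-benzofuran-2-yl in place of thiophen-2-yl on an aromatic carbon).

Among the compounds with values here, the one measured step that bears on this is a step that the two limits leave unreadable from compound 2 to compound 3, with thiophen-2-yl in place of furan-3-yl, and it offers no size to carry over. Compound 1 already carries 1-benzofuran-2-yl on a core that differs in another place, and compound 1 reads > 20000 nM, again only a limit.

No step beyond the scatter is therefore expected in this assay, and a further reading at the limit is the likeliest result. The expected change is a number no higher from compound 3 to compound 4 (the limit leaves the size open), and the data fix no direction for it. For compound 4 the estimate is 20000 nM, with an expected range from 9000 nM to 40000 nM.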

Compound 4, half-maximal inhibitory concentration: > 20000 nM
Compound 4: no number, only a limit; the forecaster's own chance of this, stated with the estimate: 80%; the middle value sits exactly at the limit.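

In this assay compound 4 gives > 20000 nM, a limit and not a number. The steps to compound 4 from compound 1, compound 2 and compound 3 therefore cannot be read: the limit of > 20000 nM in this assay, at which 4 of the 4 values shown sit.

The compounds shown leave open how these four compounds compare in this assay, and whether any change to the shared core gives a measurable value.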